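Cytotoxicity notes on the naphthyl ketone sulfonamide series

The source may hold more compounds than are shown below. What is called first, only, known or untested is meant among the compounds shown, and "the series" means these compounds.

Measured so far:
Compound 1 `Cc1cc(S(N)(=O)=O)ccc1NC(=O)COc1ccc2ccccc2c1C(=O)c1cc(Cl)cc(Br)c1` gives 36600 nM in an ADME assay on C8166 cells (Homo sapiens) for cytotoxicity, read by colorimetric assay and MTT assay; on this read-out lower numbers stand for higher toxicity in this test and higher numbers for lower toxicity in this test.
Compound 2 `Cc1cc(S(N)(=O)=O)ccc1NC(=O)COc1ccc2cc(Br)ccc2c1C(=O)c1cccc(Cl)c1` gives 6800 nM in this assay.
Compound 3 `Cc1cc(C)cc(C(=O)c2c(OCC(=O)Nc3ccc(S(N)(=O)=O)cc3C)ccc3cc(Br)ccc23)c1` gives 24500 nM in this assay.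

Compound 3 stands second highest of the three numbers. Its nearest neighbour is compound 1, whose number is higher but within the scatter of compound 3; compound 2 lies furthest from it, with a lower number beyond the scatter.

Compound 4 `Cc1cc(S(N)(=O)=O)ccc1NC(=O)COc1ccc2cc(Br)ccc2c1C(=O)c1cc(Cl)cc(Br)c1` is not yet measured. The change from compound 3 is 3-bromo-5-chlorophenyl in place of 3,5-dimethylphenyl on a carbonyl carbon. Among the measured compounds shown here, only one measured step touches this position: a 3.6-fold higher number from compound 2 to compound 3 (0.56 log units; beyond the scatter), where a halogenated aryl was exchanged for the dimethyl aryl and the number rose. The new step runs the other way, from the dimethyl aryl to a dihalogenated aryl, so a fall in the number toward compound 2 is the expectation, although compound 1, which carries the same 3-bromo-5-chlorophenyl on a different core, sits at the top of the set. The expected step is therefore a modest decrease, a 1.6-fold lower number from compound 3 to compound 4 (0.21 log units; within the scatter), with wide uncertainty. Compound 4 is estimated at 15000 nM, with a range from 6000 nM to 38000 nM in this assay.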

Compound 4, half-maximal cytotoxic concentration: 28500 nM
For compound 4 the middle estimate is 1.9-fold (0.28 log units) below the measured one; the range from low to high includes it.
By their numbers in this assay, from the lowest: compound 2; then compounds 3, 4 and 1 (each within the scatter of the next).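

Working notes, position on the carbonyl carbon. In this assay, 3-bromo-5-chlorophenyl in place of 3,5-dimethylphenyl gives a 1.2-fold higher number from compound 3 to compound 4 (0.07 log units; within the scatter) and so shows that, on the shared core, these two aryl groups are not told apart by this read-out, a dihalogenated aryl being no sign of a low number here. The low number of compound 2 now has a second comparison, as bromo in place of hydrogen on an aromatic carbon of its 3-chlorophenyl gives a 4.2-fold higher number from compound 2 to compound 4 (0.62 log units; beyond the scatter) and matches the dimethyl comparison in direction, while the same kind of exchange on the core, with 3-bromo-5-chlorophenyl held in place, gives a 1.3-fold lower number from compound 1 to compound 4 (0.11 log units; within the scatter) and stays inside the scatter. Nothing available explains why compound 2 alone stands apart from compound 3 and compound 4.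

Still open, as far as these compounds go, is whether the number on this core follows the presence of a second group on the aryl ring or the identity of the two groups, which a 3,5-dimethoxyphenyl or a 3-amino-5-chlorophenyl at the same position would test. Also open, from the compounds shown here alone, is whether a carboxylic acid on this aryl ring would leave the number where compound 3 and compound 4 stand.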